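A few compounds are considered here, and "the series" means these few. Any claim that something is new, unique, unknown or untested is made for them only; others in the source may bear on it.

Compound 1 `CC(C)[C@H](NC(=O)COc1cccc2ccccc12)C(=O)N[C@@H](CC(=O)O)C(=O)COc1ccc(C(N)=O)cc1`: in a functional assay on Jurkat cells (Homo sapiens) (a higher number here means a weaker inhibitor, a lower number a stronger inhibitor), compound 1 stops at > 100000 nM, a limit of the assay and not a number.
Compound 2 `CC(C)[C@H](NC(=O)COc1cccc2ccccc12)C(=O)N[C@@H](CC(=O)O)C(=O)COc1c(F)cccc1F`: in this assay compound 2 gives 2040 nM.

Compound 1 therefore stands only at a limit, with no number of its own (the limit of > 100000 nM in this assay, at which 1 of the 2 values shown sits). Compound 3 `CC(C)[C@H](NC(=O)COc1cccc2ccccc12)C(=O)N[C@@H](CC(=O)O)C(=O)COc1cc(F)c(F)cc1F` differs from compound 1 in one place: 2,4,5-trifluorophenyl in place of 4-carbamoylphenyl on an oxygen on a saturated carbon. For the measured compounds named here, the single measured step that bears on this change is an at least 49-fold lower number from compound 1 to compound 2 (1.69 log units; beyond the scatter), where a 2,6-difluorophenyl took the place of the same 4-carbamoylphenyl on an oxygen on a saturated carbon. A 2,4,5-trifluorophenyl entering at the same place carries the same kind of change, and so for compound 3 the same direction and a similar size are expected, an at least 40-fold lower number from compound 1 to compound 3 (1.60 log units; beyond the scatter). Compound 3 is thus estimated at 2500 nM in this assay, with a range from 600 nM to 12000 nM.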

Compound 3, half-maximal inhibitory concentration: 39300 nM
Compound 3: middle estimate off by 16-fold (1.20 log units), on the low side, and the stated range ends below it.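

Two fluorinated phenyl groups on this oxygen turn out to be far from interchangeable: replacing 2,6-difluorophenyl with 2,4,5-trifluorophenyl gives a 19-fold higher number from compound 2 to compound 3 (1.28 log units; beyond the scatter). Replacing 4-carbamoylphenyl with 2,4,5-trifluorophenyl still gives an at least 2.5-fold lower number from compound 1 to compound 3 (0.40 log units; beyond the scatter), so the direction of the earlier step holds for a second fluorinated group, while its size does not carry over. The size of this step remains open-ended, as compound 1 stands only at a limit: the limit of > 100000 nM in this assay, at which 1 of the 3 values shown sits.

From the compounds shown here alone, how much of the gap between compound 2 and compound 3 belongs to the number of fluorine atoms and how much to where they stand remains open, as the two groups differ in both. Also open, going by these compounds, is where an unsubstituted phenyl or a pentafluorophenyl on this oxygen would fall in this assay.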